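The compounds below may be only part of what the source reports. "The series", "measured", "known", "first", "only" and "open" are said of these compounds alone.

In a functional assay on KB cells (Homo sapiens) for cytotoxicity (on this read-out lower numbers stand for an effect already at smaller amounts and higher numbers for an effect only at larger amounts of compound), compound 1 (`COC1=C(C)C(=O)/C(=C(O)/C=C/c2ccccc2C)C(=O)C1(C)C`) gives 4.1 ug/mL and compound 2 (`CCc1ccc(/C=C/C(O)=C2/C(=O)C(C)=C(OC)C(C)(C)C2=O)cc1`) gives 6.9 ug/mL. Among the compounds with values here, these are the only two numbers so far, and they lie within the scatter of each other, so the data do not separate compound 2 from compound 1. Compound 3 (`COC1=C(C)C(=O)/C(=C(O)/C=C/c2cccs2)C(=O)C1(C)C`) keeps the shared core and differs from compound 2 as follows: thiophen-2-yl in place of 4-ethylphenyl on a double-bonded chain carbon bound to a double-bonded chain carbon. Within the data shown here, one measured step bears on this place: a 1.7-fold higher number from compound 1 to compound 2 (0.23 log units; within the scatter), an exchange of one substituted phenyl for another that stays within the scatter. Neither measured compound has a five-membered aromatic ring here, so this step is only a loose guide. No change beyond the scatter is therefore expected in this assay. The expected step is a 1.4-fold lower number from compound 2 to compound 3 (0.14 log units; within the scatter), with no firm direction. For compound 3 the estimated value is 5 ug/mL, with an expected range from 2 ug/mL to 12 ug/mL.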

Compound 3, concentration for half-maximal effect: 5.5 ug/mL
The estimate for compound 3 lay 1.1-fold (0.04 log units) below the measured number; measured number inside the range.
By their numbers in this assay, from the lowest: compounds 1, 3 and 2 (each within the scatter of the next).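

In this assay, within the data shown here, the series now holds a five-membered aromatic ring with a sulfur atom on a double-bonded chain carbon bound to a double-bonded chain carbon, where the earlier compounds held only substituted phenyl rings. The exchange for thiophen-2-yl reads a 1.3-fold lower number from compound 2 to compound 3 (0.10 log units; within the scatter) and a 1.3-fold higher number from compound 1 to compound 3 (0.13 log units; within the scatter) and so stays within the scatter against both phenyl compounds, even though thiophen-2-yl has fewer heavy atoms than 4-ethylphenyl. No data are at hand that would explain why the three numbers stay this close.

All three groups at this place are aromatic rings, so the compounds shown do not reveal any group here that moves the number beyond the scatter. Going by these compounds, whether a carboxylic acid, an aminomethyl group or a longer alkyl chain in place of the ring would do so stays open.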